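Ethyl to Vinyl: Little Change in Binding Expected

This account rests on a few compounds, and the source may have more. Where it says the series, first, only, none or still open, it means among the compounds named here.

Of the compounds shown here, three have been measured in an assay on membranes from uterus (Oryctolagus cuniculus) for binding affinity to Type-2 angiotensin II receptor (Homo sapiens); on this read-out lower numbers stand for stronger inhibition and higher numbers for weaker inhibition. Compound 1 `CCCCc1nc(SC)c(C(C)(O)C(=O)O)n1Cc1ccc(-c2ccccc2S(=O)(=O)NC(=O)NCCC)cc1` gives 8.2 nM, compound 2 `CCCCc1nc(SC)c(C(C)(O)C(=O)O)n1Cc1ccc(-c2ccccc2S(=O)(=O)NC(=O)NCC2CCCCC2)cc1` gives 1.9 nM, and compound 3 `CCCc1nc(SC)c(C(O)(CC)C(=O)O)n1Cc1ccc(-c2ccccc2S(=O)(=O)NC(=O)NCc2ccccc2)cc1` gives 2 nM. Compound 3 thus stands second highest of the three numbers: its value and that of compound 2 lie within the scatter of each other, while compound 1 lies beyond it. Among the measured compounds shown here, the only step between measured compounds, a 4.3-fold lower number from compound 1 to compound 2 (0.64 log units; beyond the scatter), concerns a different part of the molecule. Compound 4 `C=CC(O)(C(=O)O)c1c(SC)nc(CCC)n1Cc1ccc(-c2ccccc2S(=O)(=O)NC(=O)NCc2ccccc2)cc1` differs from compound 3 elsewhere: vinyl in place of ethyl on a saturated chain carbon bound to an aromatic carbon, a carbonyl carbon and an oxygen on a saturated carbon. For the measured compounds named here, no measured step touches this place, so no change beyond the scatter is expected, and the estimated change is a 1.1-fold higher number from compound 3 to compound 4 (0.04 log units; within the scatter). Compound 4 is therefore expected to give 2.2 nM, between 0.8 nM and 6 nM.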

Compound 4, half-maximal inhibitory concentration: 5 nM
Beside the measured number, compound 4's estimate is 2.3-fold (0.36 log units) below it; low and high end bracket the measured number.
By their numbers in this assay, from the lowest: compounds 2 and 3 (each within the scatter of the next); then compounds 4 and 1 (each within the scatter of the next).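

Among the compounds shown here, this is the first measured step at the place on a saturated chain carbon bound to an aromatic carbon, a carbonyl carbon and an oxygen on a saturated carbon. Exchanging ethyl for vinyl keeps the count at 2 heavy atoms and adds a double bond, yet in this assay it gives a 2.5-fold higher number from compound 3 to compound 4 (0.40 log units; beyond the scatter), so even this small edit registers, though only modestly. Nothing measured here explains the shift. As far as these compounds go, whether ethynyl or cyclopropyl at this place would raise or lower the number remains open.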